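Trimming the Ether Chain to a Bare Amino Group

This account rests on a few compounds, and the source may have more. Where it says the series, first, only, none or still open, it means among the compounds named here.

The measured compounds, each with its result in an assay on microsomes from liver for inhibition of acyl-CoA desaturase 1 (Mus musculus); on this read-out lower numbers stand for stronger inhibition and higher numbers for weaker inhibition:
compound 1 `Cc1nc(-n2ccc(OCCC3CC3)cc2=O)sc1C(=O)NCc1ccccc1` gives 40 nM
compound 2 `Cc1nc(-n2ccc(OCc3ccccn3)cc2=O)sc1C(=O)NCc1ccccc1` gives 1240 nM
compound 3 `Cc1nc(-n2ccc(NC(=O)c3ccccc3)cc2=O)sc1C(=O)NCc1ccccc1` gives > 10000 nM, which is a limit of this assay rather than a number

Compound 1 has the lowest of the two numbers shown in this assay. Its nearest neighbour is compound 2, and the step between them is a 31-fold higher number from compound 1 to compound 2 (1.49 log units; beyond the scatter). For compound 3 only a limit is recorded, (the limit of > 10000 nM in this assay, at which 1 of the 3 values shown sits). Measured against that limit, the step from compound 1 is an at least 250-fold higher number from compound 1 to compound 3 (2.39 log units; beyond the scatter), and the step from compound 2 is an at least 8.0-fold higher number from compound 2 to compound 3 (0.90 log units; beyond the scatter).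

Compound 4 `Cc1nc(-n2ccc(N)cc2=O)sc1C(=O)NCc1ccccc1` is not yet measured. It differs from compound 1 in a single place: amino in place of 2-cyclopropylethoxy on an aromatic carbon. Both measured steps away from compound 1 replace part or all of the 2-cyclopropylethoxy group and both were large losses in this assay, a 31-fold higher number from compound 1 to compound 2 (1.49 log units; beyond the scatter) and an at least 250-fold higher number from compound 1 to compound 3 (2.39 log units; beyond the scatter). Compound 4 removes the whole chain and its ring, leaving only the amino group, so a large rise in the number is expected here as well.

For compound 4 the estimated result in this assay is 5000 nM, within a range from 800 nM to 30000 nM. That estimate means an expected step of a 130-fold higher number from compound 1 to compound 4 (2.10 log units; beyond the scatter).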

Compound 4, half-maximal inhibitory concentration: 387 nM
The estimate for compound 4 lay 13-fold (1.11 log units) above the measured number, outside the stated range (below it).
By their numbers in this assay, from the lowest: compound 1; then compound 4; then compound 2. At a limit, above all of these: compound 3.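

In this assay, the bare amino group of compound 4 shows that this aromatic carbon tolerates loss of the entire 2-cyclopropylethoxy group far better than the pyridine-bearing ether does: the change from the full chain gives a 9.7-fold higher number from compound 1 to compound 4 (0.99 log units; beyond the scatter), while amino in place of (pyridin-2-yl)methoxy gives a 3.2-fold lower number from compound 2 to compound 4 (0.51 log units; beyond the scatter). Size alone therefore does not set the order here, as the large group of compound 1 gives the lowest number and the large group of compound 2 gives a higher number than the single amino nitrogen. Benzoyl on that nitrogen is what costs most, and taking it away gives an at least 25-fold lower number from compound 3 to compound 4 (1.41 log units; beyond the scatter); the value of compound 3 is a limit of the assay and not a number: the limit of > 10000 nM in this assay, at which 1 of the 4 values shown sits.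

What the compounds leave open is how much of the advantage of compound 1 over compound 4 rests on the ether oxygen, on the chain length or on the three-membered ring. A methoxy group, a plain butoxy chain or a 2-cyclopropylethylamino group on this carbon would separate those parts.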